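The source may report more compounds than this note shows. Statements on the series, on what has been measured and on what is new or still open speak of the compounds shown alone.

Working notes on the series. In an assay on SH-EP1 cells for agonist activity at Neuronal acetylcholine receptor; alpha4/beta2 (Homo sapiens), read by FLIPR and calcium flux (on this read-out higher numbers stand for an effect only at larger amounts of compound and lower numbers for an effect already at smaller amounts), compound 1 `O=C([C@@H]1C[C@@H]1F)N1CC2CC(C1)N2` gives 370 nM and compound 2 `C[C@@H]1C[C@H]1C(=O)N1CC2CC(C1)N2` gives 2900 nM, the higher of the two numbers, the gap being a 7.8-fold higher number from compound 1 to compound 2 (0.89 log units; beyond the scatter). Compound 3 `C[C@H]1C[C@@H]1C(=O)N1CC2CC(C1)N2` differs from compound 2 only in that (the two compounds have the same atoms and bonds; at least one stereo element is drawn with a configuration in one of them and without one in the other: 2 of 4 stereo elements differ; a stereocentre at a saturated ring carbon is drawn R in compound 2 and S in compound 3; a stereocentre at a saturated ring carbon is drawn R in compound 2 and S in compound 3). Among the compounds with values here, the single measured step swaps the group on the carbonyl carbon and leaves the stereocentres alone, so no measured step bears on an inversion, and the two numbers give no direction for it. Compound 3 is therefore expected near 2900 nM (range 600 nM to 12000 nM). The expected step from compound 2 to compound 3 is no change at the digits printed from compound 2 to compound 3 (within the scatter), not beyond the scatter in either direction.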

Compound 3, half-maximal effective concentration: 14000 nM
Compound 3: the middle estimate sits 4.8-fold (0.68 log units) below what was measured; measured number above the stated range.
By their numbers in this assay, from the lowest: compound 1; then compound 2; then compound 3.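

In this assay, configuration alone moves the read-out for the 2-methylcyclopropyl amide, with atoms and bonds unchanged: a 4.8-fold higher number from compound 2 to compound 3 (0.68 log units; beyond the scatter). The size of the swap of 2-fluorocyclopropyl for 2-methylcyclopropyl on the carbonyl carbon therefore depends on the configuration compared, with a 7.8-fold higher number from compound 1 to compound 2 (0.89 log units; beyond the scatter) against a 38-fold higher number from compound 1 to compound 3 (1.58 log units; beyond the scatter). The reading of the inversion carries one reservation: the fact that one of compounds 2 and 3 is drawn with a defined configuration and the other without, at the place where they differ

From the compounds shown here alone, whether inverting the 2-fluorocyclopropyl group shifts the number likewise stays open. Also open, going by these compounds, is how an amine or a carboxylic acid would read in place of the fluorine or the methyl.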